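This account rests on a few compounds, and the source may have more. Where it says the series, first, only, none or still open, it means among the compounds named here.

Of the compounds shown here, three sharing one core have been measured in an assay on isolated protein for inhibition of G protein-coupled receptor kinase 6 (Homo sapiens), read by scintillation counting, radiometric assay and 33P incorporation, with a stated time of 80 min, in the presence of a further agent that is not named here; a higher number here means a weaker inhibitor, a lower number a stronger inhibitor. Compound 1 `CCc1cc(Nc2nc(N[C@@H](C)c3ccc(OC)cc3)nc3ccccc23)n[nH]1` gives 290 nM. Compound 2 `CCc1cc(Nc2nc(N[C@@H](C)c3ccc(F)cc3)nc3cccc(F)c23)n[nH]1` gives 41 nM, and compound 3 `CCc1cc(Nc2nc(N[C@@H](C)c3ccc(F)cc3)nc3cc(F)ccc23)n[nH]1` gives 100 nM. Among these three numbers compound 3 stands second highest: its value lies between that of compound 2, which is lower by a margin beyond the scatter, and that of compound 1, which is higher by a margin beyond the scatter. Compound 4 `CCc1cc(Nc2nc(N[C@@H](C)c3ccc(F)cc3)nc3ccccc23)n[nH]1` differs from compound 3 in one place: hydrogen in place of fluoro on an aromatic carbon. For the measured compounds named here, no measured pair separates this change on its own. The step from compound 3 to compound 4 is expected to be small, a 1.2-fold higher number from compound 3 to compound 4 (0.08 log units; within the scatter), likely within the scatter or a slight weakening. Compound 4 is therefore estimated at 120 nM, within 50 nM to 280 nM.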

Compound 4, half-maximal inhibitory concentration: 120 nM
The estimate for compound 4 equals the measured number at the digits printed; low and high end bracket the measured number.
By their numbers in this assay, from the lowest: compound 2; then compounds 3 and 4 (each within the scatter of the next); then compound 1.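

Hydrogen in place of fluoro at this carbon gives a 1.2-fold higher number from compound 3 to compound 4 (0.08 log units; within the scatter), so fluoro here is not separated from hydrogen. The same exchange on a different aromatic carbon gives a 2.9-fold higher number from compound 2 to compound 4 (0.47 log units; beyond the scatter), which shows that the outcome of this change depends on where on the ring it is made. Separately, fluoro in place of methoxy on an aromatic carbon gives a 2.4-fold lower number from compound 1 to compound 4 (0.38 log units; beyond the scatter). Nothing given here explains these differences. Going by these compounds, whether a chloro, a methyl or a methoxy at this carbon would match hydrogen and fluoro remains open.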